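Purine series: cytotoxicity limits and a methoxy step

The source may report more compounds than this note shows. Statements on the series, on what has been measured and on what is new or still open speak of the compounds shown alone.

The series shares one core; compound 1 `Oc1ccc(CNc2ncnc3c2ncn3C2CCCCO2)cc1` carries a 4-hydroxyphenyl group. In an ADME assay on BJ cells (Homo sapiens) for cytotoxicity, read by MTT assay, with a stated time of 72 h (a higher number here means a weaker inhibitor, a lower number a stronger inhibitor), compound 1 sits at a limit of the assay, > 100000 nM. Compound 2 `COc1ccccc1CNc1ncnc2c1ncn2C1CCCCO1` differs from compound 1 by 2-methoxyphenyl in place of 4-hydroxyphenyl on a saturated chain carbon bound to a nitrogen on an aromatic ring. In this assay compound 2 likewise sits at a limit, > 100000 nM. The step that the two limits leave unreadable from compound 1 to compound 2 cannot be read because of the limit of > 100000 nM in this assay, at which 3 of the 3 values shown sit. Compound 3 `COc1cc(CNc2ncnc3c2ncn3C2CCCCO2)ccc1O` differs from compound 1 by methoxy in place of hydrogen on an aromatic carbon. In this assay compound 3 again sits at a limit, > 100000 nM. The step that the two limits leave unreadable from compound 1 to compound 3 cannot be read because of the limit of > 100000 nM in this assay, at which 3 of the 3 values shown sit.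

Compound 4 `COc1cccc(OC)c1CNc1ncnc2c1ncn2C1CCCCO1` is not yet measured; it differs from compound 2 by methoxy in place of hydrogen on an aromatic carbon. This is the same kind of change as from compound 1 to compound 3, though the place differs: in compound 3 the methoxy enters ortho to a hydroxy group and meta to a large group, in compound 4 ortho to a large group and meta to a methoxy group. The step from compound 2 to compound 4 is expected to be a step that the limit leaves unreadable from compound 2 to compound 4, which rests on (the limit of > 100000 nM in this assay, at which 3 of the 3 values shown sit). Compound 4 is estimated to give 200000 nM in this assay, probably reported only as a limit, within 70000 nM to 600000 nM.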

Compound 4, half-maximal inhibitory concentration: > 100000 nM
Compound 4: a limit, no number (the forecaster's own chance of this, stated with the estimate: 85%); the middle value is on the limit's open side.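

In this assay compound 4 gives > 100000 nM as a limit and not a number. No new step can be read between compound 2 and compound 4, because both stop at a limit: the limit of > 100000 nM in this assay, at which 4 of the 4 values shown sit.
The compounds shown leave open how strongly any of them acts on these cells, and whether a methoxy change shifts that at all.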